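The source may report more compounds than this note shows. Statements on the series, on what has been measured and on what is new or still open speak of the compounds shown alone.

Four compounds share a core built around a fused two-ring system, in which a five-membered aromatic ring with two nitrogen atoms carries a small carbon group on one ring nitrogen. Compound 1 `CCCCn1cnc2c(Nc3ccccc3)nc(NCOCc3ccc(/C=C/C(=O)Nc4ccccc4N)cc3)nc21` carries a butyl there. Compound 2 `CCCCn1cnc2c(Nc3cccc(Cl)c3)nc(NCOCc3ccc(C(=O)Nc4ccccc4N)cc3)nc21` carries a butyl as well; how its core differs from that of compound 1 is not broken down here. Compound 3 `Nc1ccccc1NC(=O)c1ccc(COCNc2nc(Nc3cccc(Cl)c3)c3ncn(C4CCCC4)c3n2)cc1` differs from compound 2 in one place: cyclopentyl in place of butyl on an aromatic nitrogen. Compound 4 `Nc1ccccc1NC(=O)/C=C/c1ccc(COCNc2nc(Nc3ccccc3)c3ncn(C4CCCC4)c3n2)cc1`, not yet measured, differs from compound 1 by the same change, at the same place: cyclopentyl in place of butyl on an aromatic nitrogen.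

In a functional assay on NCI-H460 cells (Homo sapiens) for antiproliferative activity, read by CCK-8 assay, with a stated time of 72 h, tested at 2 uM (a higher number here means a stronger effect of the compound at the concentration tested, a lower number a weaker effect), compound 2 gives 56.9% and compound 3 gives 36.1%. That single swap made a number 20.8 percentage points lower from compound 2 to compound 3 (beyond the scatter). In this assay compound 1 gives 23.1%, the lowest of the three measured numbers, with compound 3 nearest to it and compound 2 furthest.

Going by the values given here, only one measured example of this change exists here, so the expectation for compound 4 rests on that one step and on the starting point of compound 1. Since compound 1 already gives only 23.1%, a drop of the earlier size would carry compound 4 close to the bottom of the scale, where there is little room left to fall. Compound 4 is therefore expected to give about 8%, within a band from -5% to 22%. The expected step is a number 15.1 percentage points lower from compound 1 to compound 4 (beyond the scatter), somewhat smaller than the earlier one.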

Compound 4, a percentage reported as inhibition, at one concentration (the size of the read-out at that concentration, not a potency): 52%
The estimate for compound 4 lay 44 percentage points below the measured number, and the stated range ends below it.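

In this assay, going by these compounds alone, putting cyclopentyl in place of butyl on the aromatic nitrogen gave a number 28.9 percentage points higher from compound 1 to compound 4 (beyond the scatter), the opposite direction to the one earlier pair. Set side by side, the two results show that this swap does not carry from one core to the other with a fixed size, or even a fixed direction: the same change on two cores in this assay, a number 20.8 percentage points lower (beyond the scatter) from compound 2 to compound 3 and a number 28.9 percentage points higher (beyond the scatter) from compound 1 to compound 4, 49.7 percentage points apart, beyond the scatter of two such steps. They do not show why the direction reverses, and each direction rests on a single pair of compounds, tested at one concentration on one cell line, so neither can be taken as a general rule for either core.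

From the compounds shown here alone, the core of compound 1 and the core of compound 2 differ in more than one place, with a chlorine on the aniline ring and a carbon-carbon double bond in the chain leading to the amide, so it remains open which of these decides how the swap turns out. Also open, going by these compounds, is how other groups on that ring nitrogen would behave on each core, such as a methyl, a longer chain like hexyl, or a larger ring like cyclohexyl.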